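Aspirin diester half-life: phenyl to (nitrooxy)methyl

The source may report more compounds than this note shows. Statements on the series, on what has been measured and on what is new or still open speak of the compounds shown alone.

Measured compounds in an ADME assay on a cell-free system (plasma, Homo sapiens) for metabolic stability, with Plasma (Rattus norvegicus) as the target, read by HPLC, at pH 7.4; on this read-out lower numbers stand for a shorter-lived compound and higher numbers for a longer-lived compound:
compound 1, `CC(=O)Oc1ccccc1C(=O)O[C@H]1CO[C@H]2[C@@H]1OC[C@H]2OC(=O)c1snnc1C`, 0.0065 h;
compound 2, `CC(=O)Oc1ccccc1C(=O)O[C@H]1CO[C@H]2[C@@H]1OC[C@H]2OC(=O)c1ccccc1`, 0.0107 h;
compound 3, `CC(=O)Oc1ccccc1C(=O)O[C@H]1CO[C@H]2[C@@H]1OC[C@H]2OC(=O)c1ccc(-c2ccccc2)cc1`, reported only as a limit, > 0.333 h.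

Compound 2 carries the higher of the two numbers, and compound 1 sits within the scatter of it, a 1.6-fold higher number from compound 1 to compound 2 (0.22 log units; within the scatter). The remaining value is a limit, (the limit of > 0.333 h in this assay, at which 1 of the 3 values shown sits). Compound 4, `CC(=O)Oc1ccccc1C(=O)O[C@H]1CO[C@H]2[C@@H]1OC[C@H]2OC(=O)CO[N+](=O)[O-]`, has not yet been measured; it differs from compound 2 at a carbonyl carbon: (nitrooxy)methyl in place of phenyl on a carbonyl carbon.

For the measured compounds named here, no measured step swaps an aromatic group for an open chain. Going by the values given here, the one small change, a 1.6-fold higher number from compound 1 to compound 2 (0.22 log units; within the scatter), stayed within the scatter, while an at least 31-fold higher number from compound 2 to compound 3 (1.49 log units; beyond the scatter) was large. The new change brings no second ring, so no large rise is expected; compound 4 is estimated at 0.008 h, between 0.003 h and 0.02 h, a step of a 1.3-fold lower number from compound 2 to compound 4 (0.13 log units; within the scatter).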

Compound 4, half-life: 0.015 h
For compound 4 the middle estimate is 1.9-fold (0.27 log units) below the measured one; measured number inside the range.
By their numbers in this assay, from the lowest: compounds 1, 2 and 4 (each within the scatter of the next, the first and the last beyond it). At a limit, above all of these: compound 3.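

In this assay, an open chain on this carbonyl carbon reads much like an aromatic ring: (nitrooxy)methyl stays level with phenyl (a 1.4-fold higher number from compound 2 to compound 4 (0.15 log units; within the scatter)), though it stands apart from 4-methyl-1,2,3-thiadiazol-5-yl (a 2.3-fold higher number from compound 1 to compound 4 (0.36 log units; beyond the scatter)). The large gap remains with 4-phenylphenyl alone (an at least 22-fold lower number from compound 3 to compound 4 (1.34 log units; beyond the scatter)). Compound 3 gives only a limit, not a number: (the limit of > 0.333 h in this assay, at which 1 of the 4 values shown sits).

Going by these compounds, what a plain methyl without the nitrooxy part, a longer chain or an amine on this carbonyl carbon would give remains open.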